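The compounds below may be only part of what the source reports. "The series", "measured", "known", "first", "only" and "open" are said of these compounds alone.

Measured so far:
- compound 1 `CCN(CC)S(=O)(=O)c1ccc(NC(=O)c2ccccc2)c2ccccc12` — in an assay on L1.2 cells for binding affinity to C-C chemokine receptor type 8 (Homo sapiens) (a lower number here means a stronger inhibitor, a higher number a weaker inhibitor), compound 1 gives > 30000 nM, which is a limit of the assay.
- compound 2 `CCOC(=O)N1CCC(NS(=O)(=O)c2ccc(C(=O)NC3CCCCC3)c3ccccc23)CC1` — in this assay compound 2 gives 9.5 nM.

Within the data shown here, compound 2 supplies the only number in this assay. The value for compound 1 is a limit and not a number (the limit of > 30000 nM in this assay, at which 1 of the 2 values shown sits). Among the measured compounds shown here, no pair of measured compounds differs in a single place, so no measured step exists to lean on.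

Compound 3 `CCOC(=O)N1CCC(NS(=O)(=O)c2ccc(OC(=O)c3ccccc3)c3ccccc23)CC1` differs from compound 2 in one place: benzoyloxy in place of cyclohexylcarbamoyl on an aromatic carbon. The group that leaves carries a hydrogen-bond donor; the group that enters carries none. For the measured compounds named here, with no measured step of this kind, the expectation for compound 3 rests on the change alone; a loss in this assay beyond the scatter is expected, estimated as a 26-fold higher number from compound 2 to compound 3 (1.42 log units; beyond the scatter). Compound 3 is expected to give 250 nM, within a range of 30 nM to 3000 nM.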

Compound 3, inhibition constant: 16.4 nM
Beside the measured number, compound 3's estimate is 15-fold (1.18 log units) above it, and the stated range ends above it.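

In this assay, the exchange on the aromatic carbon para to a large group gives a 1.7-fold higher number from compound 2 to compound 3 (0.24 log units; within the scatter), so benzoyloxy and cyclohexylcarbamoyl cannot be told apart at this position. The pair therefore shows that, on this core, the position accepts a group with no hydrogen-bond donor and a six-membered aromatic ring in place of a group with one hydrogen-bond donor and a six-membered non-aromatic ring, with no change beyond the scatter. No measured property bears on this step.

The donor, the ring type and the linking atoms all change together in this one pair, so their separate contributions remain unresolved. Also open, as far as these compounds go, is how a free amine, a carboxylic acid or a longer chain on this aromatic carbon would read in this assay.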